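Extending an Alkoxy Chain on a Quinone Core

The compounds below may be only part of what the source reports. "The series", "measured", "known", "first", "only" and "open" are said of these compounds alone.

compound 1 `CCOC1=CC(=O)c2ccccc2C1=O`: 16900 nM
compound 2 `O=C(Oc1ccc2c(c1)C(=O)C=CC2=O)c1ccccc1`: 12100 nM
compound 3 `COc1ccc2c(c1)C(=O)C=CC2=O`: 33900 nM

In a functional assay on KB cells (Homo sapiens) for cytotoxicity (on this read-out lower numbers stand for stronger inhibition and higher numbers for weaker inhibition), compound 1 gives 16900 nM, the second highest of the three numbers. Compound 2 shows a lower number and compound 3 a higher one, but both gaps to compound 1 lie within the scatter, so no order among the three can be stated. Compound 4 `CCCCOC1=CC(=O)c2ccccc2C1=O` differs from compound 1 by ethyl in place of hydrogen on a saturated chain carbon, two bonds along the chain from an oxygen on an unsaturated carbon. Going by the values given here, no measured pair shows this change, so nothing from the data points to a shift in either direction. The step expected here is a 1.3-fold lower number from compound 1 to compound 4 (0.11 log units; within the scatter), no larger than the scatter. Compound 4 is therefore estimated at 13000 nM, with a range from 5500 nM to 32000 nM.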

Compound 4, half-maximal inhibitory concentration: 27000 nM
Compound 4: middle estimate off by 2.1-fold (0.32 log units), on the low side, within the range that was stated.
By their numbers in this assay, from the lowest: compounds 2, 1, 4 and 3 (each within the scatter of the next, the first and the last beyond it).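

Going by these compounds alone, the pair of compound 1 and compound 4 gives the first direct reading of ethoxy to butoxy on the shared core: in this assay this exchange gives a 1.6-fold higher number from compound 1 to compound 4 (0.20 log units; within the scatter) and so shows no effect that can be told from scatter. At this saturated chain carbon, ethyl in place of hydrogen therefore leaves the number indistinguishable from that of compound 1, on the evidence of this single pair. No measurement here bears on the reason for this result.

Going by these compounds, whether a longer chain would move the number beyond the scatter remains open. So does the outcome of placing an amine or a carboxylic acid at the end of the chain.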